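Swapping the aryl ether group on a prostacyclin synthase inhibitor

A few compounds are considered here, and "the series" means these few. Any claim that something is new, unique, unknown or untested is made for them only; others in the source may bear on it.

Measured compounds:
compound 1, `O=C(O)CC/C=C\CC1COC(c2ccc([N+](=O)[O-])cc2)OC1c1cccnc1`, 13000 nM
compound 2, `Cc1ccc(C#N)c(OC(C)(C)C2OCC(C/C=C\CCC(=O)O)C(c3cccnc3)O2)c1`, > 100000 nM
compound 3, `Cc1ccc(OC(C)(C)C2OCC(C/C=C\CCC(=O)O)C(c3cccnc3)O2)cc1`, 25000 nM

In an assay for inhibition of prostacyclin synthase (Homo sapiens), using microsomes (a lower number here means a stronger inhibitor, a higher number a weaker inhibitor), compound 3 gives 25000 nM. Compound 1 gives 13000 nM in this assay, and the two numbers lie within the usual scatter of each other. The value of compound 2 in this assay is a limit of the assay, (the limit of > 100000 nM in this assay, at which 1 of the 3 values shown sits), not a number.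

Compound 4, `CC(C)(Oc1ccc(F)cc1[N+](=O)[O-])C1OCC(C/C=C\CCC(=O)O)C(c2cccnc2)O1`, differs from compound 3 in one place: 4-fluoro-2-nitrophenyl in place of 4-methylphenyl on an oxygen on a saturated carbon.

Within the data shown here, one measured step bears on this change. From compound 2 to compound 3 the replacement of 2-cyano-5-methylphenyl by 4-methylphenyl on the oxygen on a saturated carbon gave an at least 4.0-fold lower number from compound 2 to compound 3 (0.60 log units; beyond the scatter). Compound 4 goes the other way, back to a phenyl carrying two substituents in place of the plain 4-methylphenyl, so a step toward a higher number in this assay is expected, though the new substituents are not the ones of compound 2 and the size is uncertain.

For compound 4 a number of about 50000 nM in this assay is expected, within 12000 nM to 200000 nM, which means an expected step of a 2.0-fold higher number from compound 3 to compound 4 (0.30 log units; within the scatter) from compound 3 to compound 4, with a real chance that only a limit is reported.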

Compound 4, half-maximal inhibitory concentration: 9000 nM
Beside the measured number, compound 4's estimate is 5.6-fold (0.74 log units) above it, and the stated range ends above it.
By their numbers in this assay, from the lowest: compounds 4, 1 and 3 (each within the scatter of the next, the first and the last beyond it). At a limit, above all of these: compound 2.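

The change to 4-fluoro-2-nitrophenyl on the oxygen on a saturated carbon gives a 2.8-fold lower number from compound 3 to compound 4 (0.44 log units; beyond the scatter) in this assay, so a phenyl carrying two substituents at this place can give a lower number than the plain 4-methylphenyl, which the earlier step alone did not show. Set against 2-cyano-5-methylphenyl, which also puts two substituents on the phenyl, the same group gives an at least 11-fold lower number from compound 2 to compound 4 (1.04 log units; beyond the scatter), so at this place the outcome depends on which substituents the phenyl carries and not merely on there being two of them. The value of compound 2 is a limit of the assay and not a number, so the full size of that step stays unknown: the limit of > 100000 nM in this assay, at which 1 of the 4 values shown sits.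

The compounds shown leave open whether the fluorine, the nitro group or the two together account for the lower number of compound 4, as neither substituent stands alone on the phenyl in any of them. Also open, from the compounds shown here alone, is how an amine or a carboxylic acid in place of the nitro group would read in this assay.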